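The compounds below may be only part of what the source reports. "The series", "measured", "known", "first", "only" and "open" are said of these compounds alone.

Working notes on the series. Compound 1 `CN(C)C(=O)c1cc2cnc(Nc3ccc(NC(=O)C4(C(=O)Nc5ccccc5F)CC4)cc3)nc2n1C1CCCC1` gives 70.2% in a functional assay on NCI-H1299 cells (Homo sapiens) for inhibition, read by CCK-8 assay, with a stated time of 72 h, tested at 1 uM; on this read-out lower numbers stand for less inhibition of growth and higher numbers for more inhibition of growth at the one concentration tested. Compound 2 `CN(C)C(=O)c1cc2cnc(Nc3ccc(NC(=O)C4(C(=O)Nc5ccc(Br)cc5)CC4)cc3)nc2n1C1CCCC1` gives 27.6%, the lower of the two numbers; the step of a number 42.6 percentage points lower from compound 1 to compound 2 (beyond the scatter) separates them. Compound 3 `CN(C)C(=O)c1cc2cnc(Nc3ccc(NC(=O)C4(C(=O)Nc5cccc(Br)c5)CC4)cc3)nc2n1C1CCCC1` differs from compound 2 by 3-bromophenyl in place of 4-bromophenyl on an amide-type nitrogen. For the measured compounds named here, no measured step moves the bromine within the ring; the only step at this amide-type nitrogen, a number 42.6 percentage points lower from compound 1 to compound 2 (beyond the scatter), shows that what stands there matters strongly, so a sizeable step in either direction is possible. Compound 3 is expected to land at 40% with a range of 15% to 68%, a step of a number 12.4 percentage points higher from compound 2 to compound 3 (beyond the scatter) that is an estimate only.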

Compound 3, percent growth inhibition at one concentration: 46.6%
Compound 3: the middle estimate sits 6.6 percentage points below what was measured; the range from low to high includes it.
By their numbers in this assay, from the lowest: compound 2; then compound 3; then compound 1.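

Moving the bromine alone changes the result: with the same atoms joined differently, a number 19 percentage points higher from compound 2 to compound 3 (beyond the scatter) shows that its place on the phenyl ring matters, not just its presence. 3-Bromophenyl still does not match 2-fluorophenyl, with a number 23.6 percentage points lower from compound 1 to compound 3 (beyond the scatter) in a step that changes both the halogen and its place. Open, going by these compounds, is whether the higher number of compound 1 follows the fluorine or its place; 2-bromophenyl and 4-fluorophenyl would separate the two. Also open, on these data alone, is how a methoxy group or an amine on this ring would read. No evidence available here bears on the reason for these differences.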